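The source may hold more compounds than are shown below. What is called first, only, known or untested is meant among the compounds shown, and "the series" means these compounds.

Three compounds share one core, a cyclic alkene linked through a short chain to a sulfonylurea, and differ mainly in the ring attached to the sulfonyl sulfur. Compound 1, `COc1ccc(Cl)cc1S(=O)(=O)NC(=O)NC/C=C1\CCCc2cnn(Cc3ccc(Cl)cc3Cl)c21`, carries a 5-chloro-2-methoxyphenyl there and in an assay on isolated protein for displacement of a labelled ligand from prostaglandin E2 receptor EP3 subtype (Homo sapiens), read by scintillation counting, with a stated time of 2 h (on this read-out higher numbers stand for weaker inhibition and lower numbers for stronger inhibition), compound 1 gives 3 nM. Compound 2, `Cc1nc(C)c(S(=O)(=O)NC(=O)NC/C=C2\CCCc3cnn(Cc4ccc(Cl)cc4Cl)c32)s1`, carries a 2,4-dimethyl-1,3-thiazol-5-yl instead and in this assay compound 2 gives 2 nM. The change gives a 1.5-fold lower number from compound 1 to compound 2 (0.18 log units; within the scatter). Compound 3, `O=C(NC/C=C1\CCCc2cnn(C3CCN(c4ccc(F)cc4)CC3)c21)NS(=O)(=O)c1cc(Cl)c(Cl)s1`, with a different group on the pyrazole nitrogen as well, gives 1 nM in this assay, and its value and that of compound 2 lie within the scatter of each other. Compound 2 thus sits second highest of the three numbers, all of them close together.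

Compound 4, `Cc1ncc(S(=O)(=O)NC(=O)NC/C=C2\CCCc3cnn(Cc4ccc(Cl)cc4Cl)c32)s1`, is not yet measured. It differs from compound 2 by hydrogen in place of methyl on an aromatic carbon, on an aromatic carbon of a five-membered aromatic ring with 1 nitrogen and 1 sulfur, next to the ring nitrogen and next to the ring atom that bears a large group. For the measured compounds named here, only the step from compound 1 to compound 2 touches this part of the molecule, and it stayed within the scatter. Going by the values given here, no measured step removes a methyl from this ring, so the expected step in this assay is a 1.5-fold higher number from compound 2 to compound 4 (0.18 log units; within the scatter), none beyond the scatter. Compound 4 is therefore expected to give about 3 nM, with a range from 1 nM to 10 nM.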

Compound 4, inhibition constant: 7 nM
Beside the measured number, compound 4's estimate is 2.3-fold (0.37 log units) below it; low and high end bracket the measured number.
By their numbers in this assay, from the lowest: compounds 3, 2 and 1 (each within the scatter of the next, the first and the last beyond it); then compound 4.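

In this assay, for the compounds shown here, the methyl on the aromatic carbon next to the ring nitrogen and next to the ring atom that bears a large group turns out to count: replacing it with hydrogen gives a 3.5-fold higher number from compound 2 to compound 4 (0.54 log units; beyond the scatter) and is the first change on this ring to pass beyond the scatter, although the step is modest. The 2-methyl-1,3-thiazol-5-yl group also no longer matches the 5-chloro-2-methoxyphenyl group, as exchanging them gives a 2.3-fold higher number from compound 1 to compound 4 (0.37 log units; beyond the scatter) whereas the 2,4-dimethyl-1,3-thiazol-5-yl group stayed within the scatter of it, so this one methyl decides whether the two rings can be told apart. Nothing measured here explains why the methyl matters.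

On these data alone, how an ethyl, a chlorine or an amino group on this same aromatic carbon would read remains open, so it is unclear whether the methyl is needed as such or whether other groups could fill its place. Also open, as far as these compounds go, is what would happen to the methyl two ring bonds away, which is present in both compound 2 and compound 4.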